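The source may report more compounds than this note shows. Statements on the series, on what has been measured and on what is new or still open speak of the compounds shown alone.

Working notes on the series.

Compound 1 `COC(=O)c1cc2cc(NCc3cc(NC(=O)c4cncc(C)c4)ccc3C)cnc2[nH]1` gives in a functional assay on HUVEC cells (Homo sapiens), read by MTT assay, with a stated time of 72 h (on this read-out lower numbers stand for an effect already at smaller amounts and higher numbers for an effect only at larger amounts of compound), only a limit, > 1000 nM. That reading is the limit of > 1000 nM in this assay, at which 1 of the 3 values shown sits. Compound 2 `COC(=O)c1cc2cc(NCc3cc(NC(=O)c4ccnc(C)c4)ccc3C)cnc2[nH]1` gives 986 nM in this assay, and compound 3 `COC(=O)c1cc2cc(NCc3cc(NC(=O)c4cncc(C(F)(F)F)c4)ccc3C)cnc2[nH]1` gives 390 nM. Between the measured pairs, the change of the aryl on the carbonyl carbon gave an at least 1.0-fold lower number from compound 1 to compound 2 (0.00 log units; that floor lies within the scatter), while exchange of the methyl for trifluoromethyl gave an at least 2.5-fold lower number from compound 1 to compound 3 (0.40 log units; beyond the scatter) and the combined swap gave a 2.5-fold lower number from compound 2 to compound 3 (0.40 log units; beyond the scatter). Compound 3 therefore stands lowest of the two numbers given, with compound 2 as the nearest number beyond the scatter; the third value is a limit.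

Compound 4 `COC(=O)c1cc2cc(NCc3cc(NC(=O)c4ccc5[nH]ccc5c4)ccc3C)cnc2[nH]1` carries a different aryl on the same carbonyl carbon: 1H-indol-5-yl in place of 5-(trifluoromethyl)pyridin-3-yl on a carbonyl carbon. Going by the values given here, the steps that bear on this position are the two that changed the aryl, and both were modest at most. The entering group departs further from the measured set than any of those steps, so the direction is open; a step of modest size, most likely toward a higher number in this assay, is expected, a 1.5-fold higher number from compound 3 to compound 4 (0.19 log units; within the scatter). Compound 4 is accordingly estimated at 600 nM, within 200 nM to 1800 nM.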

Compound 4, half-maximal effective concentration: 199 nM
Compound 4: the middle estimate sits 3.0-fold (0.48 log units) above what was measured; the measured number lies below the stated range.
By their numbers in this assay, from the lowest: compounds 4 and 3 (each within the scatter of the next); then compound 2. At a limit, above all of these: compound 1.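

Among the groups shown on this carbonyl carbon, 1H-indol-5-yl is the only one with a five-membered aromatic ring and a hydrogen-bond donor, and in this assay it gives a 5.0-fold lower number from compound 2 to compound 4 (0.70 log units; beyond the scatter) against 2-methylpyridin-4-yl. Against 5-(trifluoromethyl)pyridin-3-yl the change gives a 2.0-fold lower number from compound 3 to compound 4 (0.29 log units; within the scatter) and thus does not separate the two groups, so among the compounds shown a pyridine ring on this carbonyl carbon is not needed for numbers of this size. The step of an at least 5.0-fold lower number from compound 1 to compound 4 (0.70 log units; beyond the scatter) starts from a limit and not from a number: the limit of > 1000 nM in this assay, at which 1 of the 4 values shown sits.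

The compounds shown do not separate the hydrogen-bond donor of 1H-indol-5-yl from its second ring, a question that a 1-methylindol-5-yl or a benzofuran-5-yl group on the same carbonyl carbon would address. Also open, on these data alone, is whether a phenyl carrying an amine or a carboxylic acid would hold numbers of this size on this carbonyl carbon, and what part the methyl ester plays, as it is the same in all four compounds.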